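A few compounds are considered here, and "the series" means these few. Any claim that something is new, unique, unknown or untested is made for them only; others in the source may bear on it.

In a functional assay on a cell-free system (plasma, Oryctolagus cuniculus) for inhibition, with stated times of 5 min, 1 min and 6 min (on this read-out lower numbers stand for stronger inhibition and higher numbers for weaker inhibition), compound 1 `CCOC(=O)c1c(C)nc(-c2cccc(C#N)c2)n1O`, with hydrogen on an oxygen on an aromatic ring, gives 17600 nM. Compound 2 `CCOC(=O)c1c(C)nc(-c2cccc(C#N)c2)n1OCC(N)=O`, with carbamoylmethyl there, is recorded at > 30000 nM, which is a limit of the assay and not a number. Compound 3 `CCOC(=O)c1c(C)nc(-c2cccc(C#N)c2)n1OCc1ccncc1`, with (pyridin-4-yl)methyl in that place, gives 6200 nM, the lowest result so far, although only two of the three results are true numbers.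

Compound 4 `CCOC(=O)c1c(C)nc(-c2cccc(C#N)c2)n1OCc1ccccc1` has phenyl in place of pyridin-4-yl on a saturated chain carbon bound to an oxygen on an aromatic ring. For the measured compounds named here, no measured step makes this exchange directly. The nearest evidence is a 2.8-fold lower number from compound 1 to compound 3 (0.45 log units; beyond the scatter), a modest step, and an at least 4.8-fold lower number from compound 2 to compound 3 (0.68 log units; beyond the scatter), which shows that the group on that chain carbon can matter. By contrast, an at least 1.7-fold higher number from compound 1 to compound 2 (0.23 log units; that floor lies within the scatter) offers only a floor. Both (pyridin-4-yl)methyl and benzyl place a six-membered aromatic ring on the same chain carbon, so no step beyond the scatter is expected in this assay, in either direction. The expected step is a 1.0-fold lower number from compound 3 to compound 4 (0.01 log units; within the scatter). For compound 4 the estimated value is 6000 nM, with an expected range of 2000 nM to 18000 nM.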

Compound 4, half-maximal inhibitory concentration: 5930 nM
Compound 4: middle estimate off by 1.0-fold (0.01 log units), on the high side; measured number inside the range.
By their numbers in this assay, from the lowest: compounds 4 and 3 (each within the scatter of the next); then compound 1. At a limit, above all of these: compound 2.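

In this assay, the step of a 1.0-fold lower number from compound 3 to compound 4 (0.02 log units; within the scatter) shows that, on a saturated chain carbon bound to an oxygen on an aromatic ring, phenyl and pyridin-4-yl cannot be told apart, so the one hydrogen-bond acceptor counted for pyridin-4-yl and not for phenyl makes no difference beyond the scatter in this pair. Benzyl in place of hydrogen gives a 3.0-fold lower number from compound 1 to compound 4 (0.47 log units; beyond the scatter), so the modest step first seen with (pyridin-4-yl)methyl now appears with a second six-membered aromatic ring, one of carbon only. Carbamoyl on that chain carbon goes against this pattern, and the step of an at least 5.0-fold lower number from compound 2 to compound 4 (0.70 log units; beyond the scatter) is only a floor, read against a limit of the assay and not a number: the limit of > 30000 nM in this assay, at which 1 of the 4 values shown sits.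

The compounds shown leave open whether a longer chain such as phenethyl, or a fluorine or methoxy group on the phenyl ring, would move the number away from that of benzyl. They also leave open how an amine or a carboxylic acid on the chain would read, and what the ethyl ester and the nitrile, shared by all four compounds, contribute.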